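Aminothiophene ketones: chloro step from compound 2 to compound 3

The source may report more compounds than this note shows. Statements on the series, on what has been measured and on what is new or still open speak of the compounds shown alone.

Two members of this series have numbers in an assay on CHO cells for positive allosteric modulation of adenosine receptor A1 (Homo sapiens), read by ERK phosphorylation, tested at 10 uM; on this read-out lower numbers stand for a stronger effect and higher numbers for a weaker effect at the one concentration tested. Compound 1 `Nc1sccc1C(=O)c1ccc(Cl)cc1` carries the chloro-bearing ring and gives 40%. Compound 2 `Nc1sc(-c2ccccc2)cc1C(=O)c1ccccc1`, which instead carries a phenyl on the thiophene and an unsubstituted ketone ring, gives 1%. For the measured compounds named here, on these two numbers compound 2 stands lowest, and its distance to compound 1 is beyond the scatter; the two compounds differ in two places, so no single step between them is defined.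

Compound 3 `Nc1sc(-c2ccccc2)cc1C(=O)c1ccc(Cl)cc1` is the next point and has not yet been measured in this assay. It differs from compound 2 by chloro in place of hydrogen on an aromatic carbon, on an aromatic carbon of a six-membered aromatic ring of carbon only, para to a large group. Going by the values given here, no measured pair isolates this change, and compound 1 cannot serve as a guide for it because 40% belongs to a structure that also lacks the phenyl on the thiophene. The step is therefore expected to stay within the scatter, with compound 3 estimated at 8%, in the range 0% to 30%, which corresponds to an expected step of a number 7 percentage points higher from compound 2 to compound 3 (within the scatter).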

Compound 3, a percentage reported as activity, at one concentration (the size of the read-out at that concentration, not a potency): 16%
The estimate for compound 3 lay 8 percentage points below the measured number; measured number inside the range.
By their numbers in this assay, from the lowest: compound 2; then compound 3; then compound 1.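

In this assay, the change from phenyl to 4-chlorophenyl now has a direct reading: a number 15 percentage points higher from compound 2 to compound 3 (beyond the scatter). Chloro in place of hydrogen on this aromatic carbon, para to a large group, therefore goes with a weaker effect at the one concentration tested, at least where the other phenyl is present. For the compounds shown here, compound 3 also gives the first one-place reading of that other phenyl, a number 24 percentage points lower from compound 1 to compound 3 (beyond the scatter), so with the chloro held constant, the added phenyl goes with a stronger effect; nothing measured on these compounds speaks to the origin of either step.

Each change rests on a single pair, so the compounds shown leave open whether the chloro step keeps its direction and size without the phenyl, or whether the phenyl step does so without the chloro. Also open, as far as these compounds go, is how fluoro, methyl or methoxy in place of the chloro would read, and whether an amine or a carboxylic acid on the added phenyl would keep the stronger effect seen for compound 2 and compound 3 relative to compound 1.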